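Exchanging a pyridine for an imidazole on a proline amide

The compounds below may be only part of what the source reports. "The series", "measured", "known", "first", "only" and "open" are said of these compounds alone.

Of the compounds shown here, three sharing one core have been tested in an assay on isolated protein for inhibition of tyrosine-protein kinase ZAP-70 (Homo sapiens), read by HTRF, tested at 10 uM; on this read-out higher numbers stand for more inhibition at the one concentration tested (going by the name of the read-out) and lower numbers for less inhibition. Compound 1 `Cc1cccc(Oc2ccnc(N3CCC[C@H]3C(=O)NCc3cccnc3)n2)c1` gives 6% in this assay. Compound 2 `CC(=O)CCCCC(=O)N1CCN(c2nccc(Oc3cccc(C)c3)n2)CC1` gives 0% in this assay, and compound 3 `O=C(C1CCN(c2nccc(Nc3ccccc3)n2)CC1)N1CC[C@@H](O)C1` gives 3%. Compound 1 is the reference point here, but its number sits within the usual scatter of both compound 3 and compound 2, so the three measurements cannot be told apart with confidence; all of them show little inhibition at the concentration tested.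

Compound 4 `Cc1cccc(Oc2ccnc(N3CCC[C@H]3C(=O)NCCCn3ccnc3)n2)c1` has not yet been measured in this assay. It differs from compound 1 in one place: 2-(1H-imidazol-1-yl)ethyl in place of pyridin-3-yl on a saturated chain carbon bound to an amide-type nitrogen. Among the measured compounds shown here, nothing among the measured compounds tracks this particular change, so there is no measured step to lean on. Given that compound 1 gives 6% and the other two compounds with the same core show similarly low numbers, the expectation is that the step of a number 1 percentage points lower from compound 1 to compound 4 (within the scatter) from compound 1 to compound 4 stays within the scatter, in no clear direction. Compound 4 is therefore estimated to give about 5% in this assay, with a range from -5% to 15%.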

Compound 4, a percentage reported as inhibition, at one concentration (the size of the read-out at that concentration, not a potency): 2%
Beside the measured number, compound 4's estimate is 3 percentage points above it, and the stated range covers the measured number.
By their numbers in this assay, from the lowest: compounds 2, 4, 3 and 1 (each within the scatter of the next).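

In this assay, among the compounds shown here, replacing pyridin-3-yl with 2-(1H-imidazol-1-yl)ethyl on a saturated chain carbon bound to an amide-type nitrogen gives a number 4 percentage points lower from compound 1 to compound 4 (within the scatter), the first step that can be read at this position. Cut one bond further out, the same difference takes (pyridin-3-yl)methyl to 3-(1H-imidazol-1-yl)propyl, so this position accepts both a different aromatic ring and a different chain length while the read-out stays low, with compound 4 at 2%. Nothing available explains why the two amides cannot be told apart on this read-out.

With only this one step at the position, and both of its numbers low, the compounds shown leave open whether any group on this amide nitrogen can move the read-out beyond the usual scatter. A terminal carboxylic acid, a primary amine or a morpholine at the end of the same chain would test this, as would a plain phenyl ring on the chain, which would separate the part played by the ring nitrogens from that of the ring itself.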